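This account rests on a few compounds, and the source may have more. Where it says the series, first, only, none or still open, it means among the compounds named here.

Two quinone-bearing compounds from this study carry the same terpenoid core. Compound 1 `CC1=CCC[C@H]2[C@](C)(CC3=CC(=O)C=C(Sc4ccccc4)C3=O)[C@@H](C)CC[C@]12C` gives 17400 nM in a functional assay on K562 cells (Homo sapiens) for cytotoxicity, read by MTT assay (on this read-out lower numbers stand for stronger inhibition and higher numbers for weaker inhibition), the higher of the two numbers seen so far. Compound 2 `CC1=CCC[C@H]2[C@](C)(CC3=CC(=O)C(Sc4ccccc4)=CC3=O)[C@@H](C)CC[C@]12C` gives 15200 nM in this assay, a number within the scatter of compound 1, so the two are not told apart. Compound 3 `CNC1=CC(=O)C=C(C[C@]2(C)[C@@H](C)CC[C@]3(C)C(C)=CCC[C@@H]23)C1=O` has not yet been measured; it differs from compound 1 by methylamino in place of phenylsulfanyl on a double-bonded ring carbon. Among the measured compounds shown here, no measured pair shows this kind of change, so the step of a 1.1-fold higher number from compound 1 to compound 3 (0.06 log units; within the scatter) is expected to be small and may fall within the scatter. Compound 3 is estimated at 20000 nM, with a likely range of 6000 nM to 60000 nM.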

Compound 3, half-maximal inhibitory concentration: 3600 nM
The estimate for compound 3 lay 5.6-fold (0.74 log units) above the measured number, outside the stated range (below it).
By their numbers in this assay, from the lowest: compound 3; then compounds 2 and 1 (each within the scatter of the next).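

In this assay, the group on this double-bonded ring carbon clearly affects the number: methylamino in place of phenylsulfanyl gives a 4.8-fold lower number from compound 1 to compound 3 (0.68 log units; beyond the scatter). Compound 1 and compound 2, which differ only in where phenylsulfanyl sits, had remained within the scatter of each other and showed no such separation. No available measurement bears on what underlies this step. From the compounds shown here alone, it remains open whether the step follows the loss of the phenyl ring or the arrival of the nitrogen, which phenylamino or a methylsulfanyl group here could separate. Going by these compounds, whether methylamino in the phenylsulfanyl position of compound 2 behaves alike also remains open.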